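Phenyl in place of hydrogen on the pyrimidine-type core

This account rests on a few compounds, and the source may have more. Where it says the series, first, only, none or still open, it means among the compounds named here.

Measured so far in a functional assay on the whole organism for inhibition, with Rattus norvegicus as the target, with stated times of 1 h and 3.5 h, at a dose of 100 mg/kg by the oral route; on this read-out higher numbers stand for more inhibition at the one dose given (going by the name of the read-out) and lower numbers for less inhibition:
compound 1 `CC(C)(C)c1nc(N)ncc1-c1ccccc1` gives 46%
compound 2 `Cc1ncc(-c2ccccc2)c(C(C)(C)C)n1` gives 22%
compound 3 `CC(C)(C)c1ncncc1-c1ccccc1` gives 48%

Compound 3 holds the highest of the three numbers; its gap to compound 1 is within the scatter, its gap to compound 2 beyond it. Compound 4 `CC(C)(C)c1nc(-c2ccccc2)ncc1-c1ccccc1` differs from compound 3 in one place: phenyl in place of hydrogen on an aromatic carbon. Within the data shown here, two measured steps touch this position: a number 2 percentage points higher from compound 1 to compound 3 (within the scatter) and a number 26 percentage points higher from compound 2 to compound 3 (beyond the scatter). Neither involves a phenyl, so the bearing is indirect; the methyl step shows that a group here can lower the number, the amino step that it need not. A modest fall is therefore expected, a number 13 percentage points lower from compound 3 to compound 4 (beyond the scatter), with wide uncertainty. Compound 4 is estimated at 35%, range 10% to 60%.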

Compound 4, a percentage reported as inhibition, in the whole organism at one dose (the size of the read-out at that dose, not a potency): < 5%
Compound 4 gave a limit, no number (the forecaster's own chance of this, stated with the estimate: 0%); at least 30 percentage points between middle value and limit.
By their numbers in this assay, from the lowest: compound 2; then compounds 1 and 3 (each within the scatter of the next). At a limit, below all of these: compound 4.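

In this assay, phenyl at this position, between two ring nitrogen atoms, brings a large fall that neither amino nor hydrogen showed: a number at least 43 percentage points lower from compound 3 to compound 4 (beyond the scatter), and a number at least 41 percentage points lower from compound 1 to compound 4 (beyond the scatter). Phenyl also goes beyond methyl, the one earlier group that lowered the number: a number at least 17 percentage points lower from compound 2 to compound 4 (beyond the scatter). Compound 4 stands at a limit and not at a number: the limit of < 5% in this assay, at which 1 of the 4 values shown sits.

On these data alone, whether the fall belongs to the aromatic ring of phenyl or would come with any larger group here remains open. A cyclohexyl ring or a longer chain such as butyl at this position would bear on that question.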